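The compounds below may be only part of what the source reports. "The series", "measured", "known", "first", "only" and "open" are said of these compounds alone.

In an ADME assay on HepG2 cells (Homo sapiens) for cytotoxicity, with a stated time of 3 days (on this read-out higher numbers stand for lower toxicity in this test and lower numbers for higher toxicity in this test), three compounds built on the same shared core have been examined so far. Compound 1, with the structure `O=C(CCSc1nnc(-c2ccncc2)s1)Nc1ccccc1`, reaches only the limit of the assay, reported as > 50000 nM. For compound 2, with the structure `O=C(CSc1nnc(-c2ccncc2)s1)NCc1ccccc1Cl`, the outcome is "not determined" (no result reported), so no number is available. Compound 3, with the structure `CC(CSc1nnc(-c2ccncc2)s1)C(=O)Nc1c(Cl)cccc1Cl`, likewise reaches only a limit of the assay, given as > 50000 nM. Its standing among the numbers shown is therefore set by the limit of > 50000 nM in this assay, at which 2 of the 3 values shown sit; compound 3 cannot be told apart from compound 1 on what is known.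

Compound 4, with the structure `CC(CSc1nnc(-c2ccncc2)s1)C(=O)NCc1ccccc1Cl`, differs from compound 3 by 2-chlorobenzyl in place of 2,6-dichlorophenyl on an amide-type nitrogen. Going by the values given here, no step between measured compounds is available to gauge what such a change does in this assay. The expectation is that compound 4 also sits at the limit, with a step of a number no higher from compound 3 to compound 4 (the limit leaves the size open) expected to be no larger than the usual scatter. Compound 4 is thus estimated at 50000 nM, with a likely range from 20000 nM to 100000 nM.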

Compound 4, half-maximal cytotoxic concentration: > 50000 nM
Compound 4: only a limit was reported (the forecaster's own chance of this, stated with the estimate: 70%); the middle value lies on the limit itself.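

Compound 3 and compound 4 each report only a limit of the assay, not a number, so no step can be read between them: the limit of > 50000 nM in this assay, at which 3 of the 4 values shown sit. The compounds shown leave open whether 2-chlorobenzyl in place of 2,6-dichlorophenyl on an amide-type nitrogen shifts the half-maximal cytotoxic concentration at all.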